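Azido in place of ethoxy on a shared core

This account rests on a few compounds, and the source may have more. Where it says the series, first, only, none or still open, it means among the compounds named here.

Measured so far in a functional assay on HFF cells (Homo sapiens) for cytotoxicity; on this read-out higher numbers stand for weaker inhibition and lower numbers for stronger inhibition

- Compound 1 `COC[C@H]1O[C@@H](n2c(Cl)nc3cc(Cl)c(Cl)cc32)[C@H](OC(C)=O)[C@@H]1OC(C)=O` gives 26000 nM
- Compound 2 `CC(=O)OC1C(CBr)OC(n2c(Cl)nc3cc(Cl)c(Cl)cc32)C1OC(C)=O` gives 32000 nM
- Compound 3 `CCOC[C@H]1OC(n2c(Cl)nc3cc(Cl)c(Cl)cc32)[C@H](O)[C@@H]1O` gives 26000 nM

Compound 3 stands at 26000 nM in this assay and matches compound 1 at the digits shown, while compound 2 lies within the scatter of both. Within the data shown here, no two measured compounds differ in only one place, so no direct step is available. Compound 4 `[N-]=[N+]=NC[C@H]1OC(n2c(Cl)nc3cc(Cl)c(Cl)cc32)[C@H](O)[C@@H]1O` carries azido in place of ethoxy on a saturated chain carbon bound to a saturated ring carbon. The three measured values stay within the scatter of one another, so no step beyond the scatter is expected in this assay and no firm direction can be given. The expected step of a 1.2-fold higher number from compound 3 to compound 4 (0.06 log units; within the scatter) is small. The estimated value for compound 4 is 30000 nM with an expected range from 12000 nM to 75000 nM in a single measurement.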

Compound 4, half-maximal inhibitory concentration: 32000 nM
Beside the measured number, compound 4's estimate is 1.1-fold (0.03 log units) below it; measured number inside the range.
By their numbers in this assay, from the lowest: compounds 1, 3, 2 and 4 (each within the scatter of the next).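

In this assay, azido in place of ethoxy on a saturated chain carbon bound to a saturated ring carbon gives a 1.2-fold higher number from compound 3 to compound 4 (0.09 log units; within the scatter), the first direct comparison available at this position. Ethoxymethyl and azidomethyl therefore cannot be told apart on this read-out, although the entering group holds only nitrogen and the leaving group holds carbon and oxygen. No supporting data explain this result. Going by these compounds, whether an amine or a carboxylic acid at this position would give a step beyond the scatter remains open.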